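Compound 3 at the Limit, and a Dichlorobenzyl Change

The compounds below may be only part of what the source reports. "The series", "measured", "known", "first", "only" and "open" are said of these compounds alone.

In a functional assay on MCF cells (Homo sapiens) for antiproliferative activity, with a stated time of 72 h (a lower number here means a stronger inhibitor, a higher number a weaker inhibitor), compound 1 `OC[C@H]1O[C@@H](n2cnc3c(NCc4ccc(F)cc4)ncnc32)[C@H](O)[C@@H]1O` gives 21000 nM. Compound 2 `OC[C@H]1O[C@@H](n2cnc3c(NCc4ccc(Br)cc4)ncnc32)[C@H](O)[C@@H]1O` gives only a limit, > 166000 nM. Compound 3 `Cc1ccc(CNc2ncnc3c2ncn3[C@@H]2O[C@H](CO)[C@@H](O)[C@H]2O)cc1` also gives only a limit, > 166000 nM. Compound 3 therefore has no number of its own and stands with compound 2 at the limit of > 166000 nM in this assay, at which 2 of the 3 values shown sit.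

Moving on to compound 4 `OC[C@H]1O[C@@H](n2cnc3c(NCc4ccc(Cl)cc4Cl)ncnc32)[C@H](O)[C@@H]1O` puts 2,4-dichlorophenyl in place of 4-methylphenyl on a saturated chain carbon bound to a nitrogen on an aromatic ring. For the measured compounds named here, three measured steps concern this same group. Methyl in place of fluoro gave an at least 7.9-fold higher number from compound 1 to compound 3 (0.89 log units; beyond the scatter), and bromo in place of fluoro gave an at least 7.9-fold higher number from compound 1 to compound 2 (0.89 log units; beyond the scatter). Both lie beyond the scatter, so changes here can matter in this assay. Methyl in place of bromo gave a step that the two limits leave unreadable from compound 2 to compound 3.

A halogen alone does not settle the outcome. Compound 1 carries fluoro and reads 21000 nM. Compound 2 carries bromo and still sits at a limit. Going by the values given here, no measured compound carries chlorine. A modest move towards a lower number is therefore expected, though compound 4 may well return only a limit too. The expected step is an at least 2.3-fold lower number from compound 3 to compound 4 (0.37 log units; beyond the scatter). For compound 4 the estimated value is 70000 nM, with an expected range from 15000 nM to 200000 nM.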

Compound 4, half-maximal inhibitory concentration: 127000 nM
Beside the measured number, compound 4's estimate is 1.8-fold (0.26 log units) below it, within the range that was stated.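

Compound 4 is the only compound shown besides compound 1 to give a number rather than a limit at this position, while the values for compound 2 and compound 3 are limits: the limit of > 166000 nM in this assay, at which 2 of the 4 values shown sit.

Replacing 4-methylphenyl with 2,4-dichlorophenyl gives an at least 1.3-fold lower number from compound 3 to compound 4 (0.11 log units; that floor lies within the scatter), and replacing 4-bromophenyl with the same group gives an at least 1.3-fold lower number from compound 2 to compound 4 (0.11 log units; that floor lies within the scatter), so both steps are floors and neither establishes a real gain. The one step with a full size, a 6.0-fold higher number from compound 1 to compound 4 (0.78 log units; beyond the scatter), leaves compound 1 as the strongest inhibitor shown in this assay, so 2,4-dichlorophenyl reads on the scale without matching 4-fluorophenyl.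

Compound 4 brings its two chlorine atoms in a single change, and the compounds shown do not separate what each one contributes. Also open, going by these compounds, is how a phenyl group carrying a single chlorine, a methoxy group or a carboxylic acid would read in this assay, and whether a change elsewhere on the shared core would move the number at all.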